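The source may hold more compounds than are shown below. What is called first, only, known or untested is meant among the compounds shown, and "the series" means these compounds.

Working notes on the series

Compound 1 `CCCn1c(=O)[nH]c2nc(-c3ccc(S(=O)(=O)N4CCN(c5ccccc5)CC4)cc3)[nH]c2c1=O` gives 0.643 nM in an assay on CHO cells for displacement of a labelled ligand from adenosine receptor A2b (Homo sapiens), read by scintillation counting, with a stated time of 75 min, in the presence of a further agent that is not named here; a higher number here means a weaker inhibitor, a lower number a stronger inhibitor. Compound 2 `CCCn1c(=O)[nH]c2nc(-c3ccc(S(=O)(=O)N4CCN(c5ccc(Cl)cc5F)CC4)cc3)[nH]c2c1=O` gives 1.91 nM, and the step of a 3.0-fold higher number from compound 1 to compound 2 (0.47 log units; beyond the scatter). Compound 3 `CCCn1c(=O)[nH]c2nc(-c3ccc(S(=O)(=O)N4CCN(c5ccccc5C)CC4)cc3)[nH]c2c1=O` gives 0.432 nM; it has the lowest number of the three, but the step of a 1.5-fold lower number from compound 1 to compound 3 (0.17 log units; within the scatter), so compounds 1 and 3 cannot be separated, while the step of a 4.4-fold lower number from compound 2 to compound 3 (0.65 log units; beyond the scatter) sets compound 3 apart from compound 2.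

Compound 4 `CCCn1c(=O)[nH]c2nc(-c3ccc(S(=O)(=O)N4CCN(Cc5ccc(Br)c(F)c5)CC4)cc3)[nH]c2c1=O` is not yet measured. The change from compound 3: 4-bromo-3-fluorobenzyl in place of 2-methylphenyl on an amine nitrogen in a ring. Both steps that exchange the group on the ring amine nitrogen bear on this: a 3.0-fold higher number from compound 1 to compound 2 (0.47 log units; beyond the scatter) and a 4.4-fold lower number from compound 2 to compound 3 (0.65 log units; beyond the scatter) both show the halogen-bearing aryl giving the higher number. Going by the values given here, no measured compound carries a benzyl at this position, so the added linking carbon is untested. The expected step is therefore a modest rise in the number, a 3.5-fold higher number from compound 3 to compound 4 (0.54 log units; beyond the scatter), with a wide range. For compound 4 the estimate is 1.5 nM, between 0.45 nM and 5 nM.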

Compound 4, inhibition constant: 0.473 nM
Estimate against measurement, compound 4: 3.2-fold (0.50 log units) above; the range from low to high includes it.
By their numbers in this assay, from the lowest: compounds 3, 4 and 1 (each within the scatter of the next); then compound 2.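

The ring amine nitrogen accepts a benzyl as well as a directly attached aryl: in this assay, the step of a 1.1-fold higher number from compound 3 to compound 4 (0.04 log units; within the scatter) and the step of a 1.4-fold lower number from compound 1 to compound 4 (0.13 log units; within the scatter) leave compound 4 inseparable from compounds 1 and 3, so the added linking carbon shows no measurable penalty here. A halogen-bearing group does not by itself go with the higher number, since the step of a 4.0-fold lower number from compound 2 to compound 4 (0.61 log units; beyond the scatter) sets compound 4, with its bromine and fluorine, clearly apart from compound 2. No measurement at hand accounts for either observation.

The compounds shown leave open whether the halogens matter on the benzyl at all, which an unsubstituted benzyl would test. Also open, on these data alone, is whether a longer chain to the aryl ring, or a carboxylic acid on that ring, would hold the number in this range.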